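Swapping chloro for phenyl on a dinitrobenzamide

A few compounds are considered here, and "the series" means these few. Any claim that something is new, unique, unknown or untested is made for them only; others in the source may bear on it.

Measured so far:
Compound 2, `O=C(Nc1cccc(Cl)c1)c1cc([N+](=O)[O-])cc([N+](=O)[O-])c1`: 33 nM
Compound 3, `COc1ccc(NC(=O)c2cc([N+](=O)[O-])cc([N+](=O)[O-])c2)cc1OC`: 1100 nM
Compound 1, `O=C(Oc1ccc(-c2ccccc2)cc1)c1cc([N+](=O)[O-])cc([N+](=O)[O-])c1`: > 50000 nM (a limit of the assay, not a number)

All three were tested in an assay on isolated protein for inhibition of Polyunsaturated fatty acid 5-lipoxygenase (Homo sapiens), read by fluorescence, with a stated time of 10 min; a lower number here means a stronger inhibitor, a higher number a weaker inhibitor. Compound 2 stands at the lowest of the two numbers shown; the nearest number, that of compound 3, is a long way higher, well beyond the scatter of repeated runs. Compound 1 gives only a limit in this assay, so nothing more than that can be said about it. None of these compounds differ from one another in a single place, so no single measured step is available to show how much one change on the aniline ring moves the number.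

Compound 4, `O=C(Nc1cccc(-c2ccccc2)c1)c1cc([N+](=O)[O-])cc([N+](=O)[O-])c1`, has not yet been measured. It differs from compound 2 by phenyl in place of chloro on an aromatic carbon. For the measured compounds named here, no measured step of this kind exists here. The expected size of the change can only be a rough guess; compound 3, far weaker than compound 2, at least shows that groups on this ring can matter a great deal. A modest loss of potency is expected, a 4.5-fold higher number from compound 2 to compound 4 (0.66 log units; beyond the scatter). Compound 4 is estimated at 150 nM, somewhere between 30 nM and 1500 nM.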

Compound 4, half-maximal inhibitory concentration: 30 nM
Estimate against measurement, compound 4: 5.0-fold (0.70 log units) above, and the stated range covers the measured number.
By their numbers in this assay, from the lowest: compounds 4 and 2 (each within the scatter of the next); then compound 3. At a limit, above all of these: compound 1.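

Phenyl in place of chloro gives a 1.1-fold lower number from compound 2 to compound 4 (0.04 log units; within the scatter) in this assay, the first measured step that isolates a single change on this ring. This shows that the position, an aromatic carbon meta to a large group, can carry a phenyl, with 6 heavy atoms and a ring of its own, in place of a chloro, with 1 heavy atom, without any change in the number beyond the scatter, so for this pair, the larger group costs nothing measurable. Nothing among the data shown bears on why these two groups give matching numbers.

From the compounds shown here alone, one pair cannot show how far this holds, so it remains open whether an amine, a carboxylic acid or a longer chain on the same carbon would also leave the number unchanged, or would move it well beyond the scatter. Going by these compounds, it also remains open whether phenyl in place of chloro would give the same result at another place on the ring, or on a different core.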